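A few compounds are considered here, and "the series" means these few. Any claim that something is new, unique, unknown or untested is made for them only; others in the source may bear on it.

Compound 2 `O=S(=O)(c1cc(Cl)cc(Cl)c1)c1cnc2c(F)cccc2c1-c1cccc(Cl)c1` is the starting point here. In an ADME assay on microsomes from liver (Homo sapiens) for metabolic stability, tested at 2.5 uM (a higher number here means faster removal of the compound, a lower number slower removal), compound 2 gives 1.2 mL/min, while compound 1 `O=S(=O)(c1cc(F)cc(F)c1)c1cnc2c(F)cccc2c1-c1cccc(Cl)c1` gives 0.64 mL/min and compound 3 `N#Cc1cccc(S(=O)(=O)c2cnc3c(F)cccc3c2-c2cccc(Cl)c2)c1` gives 1.11 mL/min. The three readings sit within the scatter of one another, as a 1.9-fold higher number from compound 1 to compound 2 (0.27 log units; within the scatter), a 1.7-fold higher number from compound 1 to compound 3 (0.24 log units; within the scatter) and a 1.1-fold lower number from compound 2 to compound 3 (0.03 log units; within the scatter) show, so compound 2 is not set apart from the others. Compound 4 `COc1cccc(-c2c(S(=O)(=O)c3cc(Cl)cc(Cl)c3)cnc3c(F)cccc23)c1` differs from compound 2 by a single change: methoxy in place of chloro on an aromatic carbon. The measured steps all alter the aryl on the sulfonyl sulfur, not this position, so none bears directly on the new change. Within the data shown here, with no step here reaching beyond the scatter, compound 4 is expected to show a 1.1-fold lower number from compound 2 to compound 4 (0.04 log units; within the scatter), giving an estimated 1.1 mL/min with a range from 0.55 mL/min to 2.2 mL/min.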

Compound 4, intrinsic clearance in a liver preparation (reported as CLH), per the amount of preparation that the assay uses: 2.31 mL/min
Estimate against measurement, compound 4: 2.1-fold (0.32 log units) below, and the stated range ends below it.
By their numbers in this assay, from the lowest: compounds 1, 3, 2 and 4 (each within the scatter of the next, the first and the last beyond it).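

Among these compounds, this is the first reading at the other aryl, away from the sulfonyl sulfur. In this assay, exchanging 3-chlorophenyl for 3-methoxyphenyl gives a 1.9-fold higher number from compound 2 to compound 4 (0.28 log units; within the scatter) and so stays within the scatter, which means this position accepts methoxy in place of chloro with no change that can be told from repeat variation. Nothing available here accounts for the reading.

Going by these compounds, what an amine, a carboxylic acid or a longer chain such as ethoxy would give at this position stays open. Also open, on these data alone, is whether methoxy reads the same alongside the 3,5-difluorophenyl or 3-cyanophenyl group on the sulfonyl sulfur.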